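This account rests on a few compounds, and the source may have more. Where it says the series, first, only, none or still open, it means among the compounds named here.

Measured so far in a functional assay on HL-60 cells (Homo sapiens) for cytotoxicity, read by WST assay, with a stated time of 48 h; on this read-out higher numbers stand for an effect only at larger amounts of compound and lower numbers for an effect already at smaller amounts:
- compound 1 `Clc1ccc(C[C@H]2COC[C@@H]2Cc2ccccc2)cc1Cl`: 19000 nM
- compound 2 `COc1ccccc1C[C@H]1COC[C@@H]1Cc1ccc(Cl)c(Cl)c1`: 55000 nM

Of these two, compound 2 gives the higher number, 55000 nM, so it needs the larger amount of compound to act. The next compound to be measured is compound 3 `CCOc1ccccc1C[C@H]1COC[C@@H]1Cc1ccc(Cl)c(Cl)c1`. It keeps the core of compound 2 and turns the methoxy into an ethoxy, with methyl in place of hydrogen on a saturated chain carbon bound to an oxygen on an aromatic ring.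

For the measured compounds named here, only one measured step bears on this change. In a 2.9-fold higher number from compound 1 to compound 2 (0.46 log units; beyond the scatter), methoxy replaced hydrogen on an aromatic carbon, and that modest step went towards a higher number. Going by the values given here, no measured pair shows what lengthening this group does, so the evidence is thin. Only a small step is expected in this assay, perhaps slightly upward and probably not beyond the scatter. The estimate means a 1.1-fold higher number from compound 2 to compound 3 (0.04 log units; within the scatter), which is the expected step. For compound 3 the expected value is 60000 nM, with an estimated range of 25000 nM to 130000 nM.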

Compound 3, half-maximal effective concentration: 29000 nM
Estimate against measurement, compound 3: 2.1-fold (0.32 log units) above; low and high end bracket the measured number.
By their numbers in this assay, from the lowest: compounds 1, 3 and 2 (each within the scatter of the next, the first and the last beyond it).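

In this assay, lengthening the methoxy of compound 2 to an ethoxy by adding one methyl gives a 1.9-fold lower number from compound 2 to compound 3 (0.28 log units; within the scatter), so this change at this place cannot be told apart from the ordinary spread of repeated measurements. Compared with the hydrogen of compound 1, the ethoxy gives a 1.5-fold higher number from compound 1 to compound 3 (0.18 log units; within the scatter), whereas the methoxy gave a 2.9-fold higher number from compound 1 to compound 2 (0.46 log units; beyond the scatter): only the methoxy step is larger than that spread, and the step to the ethoxy does not add to it. Nothing available explains why these steps come out this way.

Still open, going by these compounds, is whether a longer chain such as propoxy, or a different group such as a hydroxyl or an amine in place of the same hydrogen, would give a step that clearly exceeds the scatter. Also open, on these data alone, is whether a methoxy or ethoxy on another carbon of that aromatic ring would give a similar number.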